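Solubility across amine variants of a shared lactam core

The source may hold more compounds than are shown below. What is called first, only, known or untested is meant among the compounds shown, and "the series" means these compounds.

Measured so far:
compound 1 `COc1ccc2[nH]c(C(=O)N3CC(=O)N(Cc4ccccc4)[C@@H](CN4CCN(c5ccccn5)CC4)C3)cc2c1`, 30200 nM
compound 2 `COc1ccc2[nH]c(C(=O)N3CC(=O)N(Cc4ccccc4)[C@@H](CN4CC5CCCC5C4)C3)cc2c1`, 20700 nM
compound 3 `COc1ccc2[nH]c(C(=O)N3CC(=O)N(Cc4ccccc4)[C@@H](CN4CCC5(CCCC5)CC4)C3)cc2c1`, 5000 nM

In a physicochemical assay for solubility, read by spectrophotometry, in phosphate buffer, with a stated time of 2 h, at pH 7.4 (a lower number here means a less soluble compound, a higher number a more soluble compound), compound 3 gives the lowest of the three numbers; compound 2 is nearest, a 4.1-fold lower number from compound 2 to compound 3 (0.62 log units; beyond the scatter), and compound 1 furthest, a 6.0-fold lower number from compound 1 to compound 3 (0.78 log units; beyond the scatter). Compound 4 `COc1ccc2[nH]c(C(=O)N3CC(=O)N(Cc4ccccc4)[C@@H](CN4CCCc5ccccc54)C3)cc2c1` carries the change (a group of 10 heavy atoms (9 carbon, 1 nitrogen; one six-membered non-aromatic ring with 1 hetero atom, one six-membered aromatic ring of carbon only) in place of a group of 10 heavy atoms (9 carbon, 1 nitrogen; one five-membered non-aromatic ring of carbon only, one six-membered non-aromatic ring with 1 hetero atom), on a saturated chain carbon bound to a saturated ring carbon). For the measured compounds named here, no measured step exchanges a saturated carbon ring for an aromatic one; the steps to compound 3 only show that the saturated bicyclic amines sit lower than compound 1. The expectation for compound 4 in this assay is therefore a step of a 1.3-fold lower number from compound 3 to compound 4 (0.10 log units; within the scatter), not beyond the scatter. The estimate for compound 4 is 4000 nM, range 1500 nM to 12000 nM.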

Compound 4, solubility: 8500 nM
Beside the measured number, compound 4's estimate is 2.1-fold (0.33 log units) below it; the measured number falls inside the stated range.
By their numbers in this assay, from the lowest: compounds 3 and 4 (each within the scatter of the next); then compounds 2 and 1 (each within the scatter of the next).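

In this assay, 1,2,3,4-tetrahydroquinolin-1-yl brings an aromatic carbon ring to this place on the saturated chain carbon, and the exchange for the saturated carbon ring of compound 3 gives a 1.7-fold higher number from compound 3 to compound 4 (0.23 log units; within the scatter) with no separation between the two. The other amines stay apart, with a 2.4-fold lower number from compound 2 to compound 4 (0.39 log units; beyond the scatter) and a 3.6-fold lower number from compound 1 to compound 4 (0.55 log units; beyond the scatter) placing compound 4 in the lower pair with compound 3. No supporting data bear on the reason for these steps.

Open, on these data alone, is how morpholin-4-yl would read at this place. Also open, as far as these compounds go, is how piperazin-1-yl without the pyridine ring of compound 1 would read.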